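Replacing Amino with Fluoro in a Cytotoxic Series

A few compounds are considered here, and "the series" means these few. Any claim that something is new, unique, unknown or untested is made for them only; others in the source may bear on it.

Compound 1 `COc1ccc(-c2c(-c3cc(Cl)c(OC)c(OC)c3)ncn2C)cc1F` gives 400 nM in a functional assay on 518A2 cells (Homo sapiens) for cytotoxicity, read by MTT assay, with a stated time of 72 h; on this read-out higher numbers stand for weaker inhibition and lower numbers for stronger inhibition
Compound 2 `COc1ccc(-c2c(-c3cc(Br)c(OC)c(OC)c3)ncn2C)cc1N` gives 6.4 nM in this assay

Of these two compounds, compound 2 stands lowest at 6.4 nM and is therefore the stronger inhibitor, with a gap to compound 1 that lies beyond the scatter. The next compound to be examined is compound 3 `COc1ccc(-c2c(-c3cc(Br)c(OC)c(OC)c3)ncn2C)cc1F`, which has not yet been measured in this assay and carries fluoro in place of amino on an aromatic carbon. That carbon is ortho to a methoxy group and meta to a large group. Among the compounds with values here, no measured pair isolates this change, so its size cannot be read directly from the data. Within the data shown here, the only other guide is that fluoro-bearing compound 1 gives 400 nM as its value. A loss of potency beyond the scatter is therefore expected, with a 31-fold higher number from compound 2 to compound 3 (1.49 log units; beyond the scatter) as the estimated size of the step toward a higher number. The estimated value for compound 3 is 200 nM (40 nM to 800 nM).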

Compound 3, half-maximal inhibitory concentration: 66 nM
The estimate for compound 3 lay 3.0-fold (0.48 log units) above the measured number; measured number inside the range.
By their numbers in this assay, from the lowest: compound 2; then compound 3; then compound 1.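

With compound 3 in hand, the change at this carbon, ortho to a methoxy group and meta to a large group, can be read on its own in this assay: fluoro in place of amino gives a 10-fold higher number from compound 2 to compound 3 (1.01 log units; beyond the scatter), a large step, so the amino group of compound 2 cannot be exchanged for fluoro here without a clear loss. Compound 3 also isolates a second change elsewhere on the molecule, bromo in place of chloro on an aromatic carbon, which gives a 6.1-fold lower number from compound 1 to compound 3 (0.78 log units; beyond the scatter), a modest step, so each of the two places in which compound 1 and compound 2 differ carries a step beyond the scatter. Nothing measured here speaks to why either change moves the number.

As far as these compounds go, whether another group at the amino position, such as hydroxyl, methylamino or acetamido, would hold the number of compound 2 remains open. Also open, from the compounds shown here alone, are whether the bromo step would keep its size in a compound carrying amino rather than fluoro, and how iodo would compare with bromo and chloro at that second place.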